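A few compounds are considered here, and "the series" means these few. Any claim that something is new, unique, unknown or untested is made for them only; others in the source may bear on it.

Among the compounds with values here, compound 2 `CC1CN(c2cnc3c(C#N)nn(C(C)c4ccc(Cl)cc4Cl)c3n2)CCC1N1CCCCC1` gives the higher of the two clearance numbers measured so far. Within the data shown here, in an ADME assay on the whole organism (Rattus norvegicus) for pharmacokinetics, at a dose of 0.5 mg/kg by the intravenous route (a higher number here means faster removal of the compound, a lower number slower removal), compound 2 gives 102 mL/min/kg, while compound 1 `Cc1nn(C(C)c2ccc(Cl)cc2Cl)c2nc(N3CCC(N4CCCCC4)C(C)C3)cnc12` gives 38.3 mL/min/kg; the single step between them, a 2.7-fold higher number from compound 1 to compound 2 (0.43 log units; beyond the scatter), is the only measured change. Compound 3 `CC1CN(c2cnc3c(C(N)=O)nn(C(C)c4ccc(Cl)cc4Cl)c3n2)CCC1N1CCCCC1` carries the change (carbamoyl in place of cyano on an aromatic carbon). Among the measured compounds shown here, no measured step shows a carbamoyl entering anywhere, so the cyano step bears on this one only loosely: it shows that a change at this carbon can move the number beyond the scatter, without telling which way a carbamoyl would move it. Compound 3 is therefore expected to give a somewhat lower number in this assay than compound 2, with the step of a 1.6-fold lower number from compound 2 to compound 3 (0.20 log units; within the scatter) lying near the edge of the scatter. For compound 3 the estimate is 65 mL/min/kg, with a range from 28 mL/min/kg to 150 mL/min/kg.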

Compound 3, clearance: 102 mL/min/kg
Compound 3: middle estimate off by 1.6-fold (0.20 log units), on the low side, within the range that was stated.
By their numbers in this assay, from the lowest: compound 1; then compounds 2 and 3 (each within the scatter of the next).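

In this assay, carbamoyl in place of cyano on this aromatic carbon gives no change at the digits printed from compound 2 to compound 3 (within the scatter), so the two groups are not told apart here despite the hydrogen-bond donor that carbamoyl brings. Carbamoyl in place of methyl gives a 2.7-fold higher number from compound 1 to compound 3 (0.43 log units; beyond the scatter), so among these three compounds methyl alone stands apart from the other two, and the earlier cyano step is no longer a feature of cyano only. Nothing on hand accounts for this result.

Open, from the compounds shown here alone, is whether an aminomethyl group, a carboxylic acid or a longer chain such as ethyl on this carbon would sit with methyl or with cyano and carbamoyl. Also open, going by these compounds, is whether the same pattern would hold with a group other than the 1-(2,4-dichlorophenyl)ethyl group on the shared core.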